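Swapping the terminal aryl group at the tolerated end

This account rests on a few compounds, and the source may have more. Where it says the series, first, only, none or still open, it means among the compounds named here.

In a toxicity assay on MT4 cells (Homo sapiens) for cytotoxicity, read by MTT assay, with a stated time of 5 days (a higher number here means that more compound is tolerated, a lower number that less compound is tolerated), compound 1 (`Cc1cnc(Nc2ccc(C#N)cc2)nc1Nc1c(F)cc(-c2ccco2)cc1F`) gives 8100 nM. Among the measured compounds shown here, compound 2 (`Cc1cnc(Nc2ccc(C#N)cc2)nc1Nc1c(F)cc(-c2ccsc2)cc1F`) gives 261000 nM, the higher of the two numbers so far. For the measured compounds named here, the one measured step, a 32-fold higher number from compound 1 to compound 2 (1.51 log units; beyond the scatter), is large and beyond the scatter, and it exchanges furan-2-yl for thiophen-3-yl on an aromatic carbon. Compound 3 (`Cc1cnc(Nc2ccc(C#N)cc2)nc1Nc1c(F)cc(-c2cncc(C(F)(F)F)c2)cc1F`) keeps the shared core and carries 5-(trifluoromethyl)pyridin-3-yl in place of thiophen-3-yl on an aromatic carbon. That earlier step shows that a change at this place can move the number far, but it involves no six-membered aromatic ring, so its direction does not transfer directly. With compound 2 at 261000 nM, the top of a two-value range, a move downward is the more likely outcome. The expected change is a 6.5-fold lower number from compound 2 to compound 3 (0.81 log units; beyond the scatter). For compound 3 the estimate is 40000 nM, with an expected range of 6000 nM to 250000 nM.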

Compound 3, half-maximal cytotoxic concentration: 8200 nM
Compound 3: middle estimate off by 4.9-fold (0.69 log units), on the high side; the range from low to high includes it.
By their numbers in this assay, from the lowest: compounds 1 and 3 (each within the scatter of the next); then compound 2.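

In this assay the step of a 32-fold lower number from compound 2 to compound 3 (1.50 log units; beyond the scatter) shows that a six-membered aromatic ring at this place can bring the number down from the level of compound 2, so the top of the range so far belongs to thiophen-3-yl alone among the three groups. The step of a 1.0-fold higher number from compound 1 to compound 3 (0.01 log units; within the scatter) puts 5-(trifluoromethyl)pyridin-3-yl and furan-2-yl level, so ring size alone does not separate the values here, and compound 2 is the one that stands apart. No measurement at hand bears on the reason for these steps.

As far as these compounds go, the pyridine ring and its trifluoromethyl group enter together, so their separate shares in the step stay open. From the compounds shown here alone, whether a plain phenyl ring, or a ring carrying an amine or a carboxylic acid, would stand with compound 2 or with compounds 1 and 3 is also open.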